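Amine trimming on the benzylic side chain: compound 3

The compounds below may be only part of what the source reports. "The series", "measured", "known", "first", "only" and "open" are said of these compounds alone.

Compound 2 `Cc1csc2cc([C@H](C)Nc3ncnc(N)c3C#N)c(Cc3cccc(CN(C)C)c3)c(=O)n12` holds the higher of the two numbers in an ADME assay on the whole organism (lung, Rattus norvegicus) for metabolic stability, read by LC-MS (a higher number here means that the compound lasts longer, a lower number that the compound disappears faster), giving 2.3 h, while compound 1 `Cc1csc2cc([C@H](C)Nc3ncnc(N)c3C#N)c(Cc3cccc(CN4CCC4)c3)c(=O)n12` gives 1.1 h. Going by the values given here, the only measured step, a 2.1-fold higher number from compound 1 to compound 2 (0.32 log units; beyond the scatter), concerns the same amine on the benzylic chain. Compound 3 `CNCc1cccc(Cc2c([C@H](C)Nc3ncnc(N)c3C#N)cc3scc(C)n3c2=O)c1` differs from compound 2 by hydrogen in place of methyl on an amine nitrogen. Among the compounds with values here, that single step is the sole guide, so the expected change in this assay is a 1.1-fold higher number from compound 2 to compound 3 (0.04 log units; within the scatter), nothing beyond the scatter in either direction. Compound 3 is therefore estimated at 2.5 h, with a range of 1.2 h to 5 h in this assay.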

Compound 3, half-life in the lung assay: 4.9 h
Compound 3: middle estimate off by 2.0-fold (0.29 log units), on the low side, and the stated range covers the measured number.
By their numbers in the lung assay, from the lowest: compound 1; then compound 2; then compound 3.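

In the lung assay the amine on the benzylic chain keeps moving the half-life past the first change: hydrogen in place of methyl gives a 2.1-fold higher number from compound 2 to compound 3 (0.33 log units; beyond the scatter) and methylamino in place of azetidin-1-yl gives a 4.5-fold higher number from compound 1 to compound 3 (0.65 log units; beyond the scatter) in the same direction. In a physicochemical assay for solubility (on this read-out higher numbers stand for higher solubility and lower numbers for lower solubility), compound 2 gives 956000 nM as its solubility. In the physicochemical assay compound 3 gives > 1000000 nM as a limit of the assay and not a number, so the step ending there cannot be read: the limit of > 1000000 nM in the physicochemical assay, at which 1 of the 2 values shown sits.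

Going by these compounds, whether the order continues with an unsubstituted aminomethyl group stays open. A longer chain on the amine nitrogen, or a carboxylic acid at this place, also remains untested among the compounds shown.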